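The source may hold more compounds than are shown below. What is called first, only, known or untested is meant among the compounds shown, and "the series" means these compounds.

Compound 2 `Nc1nc(NCCNc2ncc(-c3ncc[nH]3)c(-c3cc(F)ccc3Cl)n2)ccc1[N+](=O)[O-]` is one of two measured compounds; the other is compound 1 `Nc1nc(NCCNc2ncc(-c3ncc[nH]3)c(-c3cc(F)c(F)cc3F)n2)ccc1[N+](=O)[O-]`. In an ADME assay on microsomes from liver (Canis lupus familiaris) for metabolic stability (a higher number here means that the compound lasts longer, a lower number that the compound disappears faster), compound 2 gives only a limit, > 0.5 h. In this assay compound 1 likewise gives only a limit, > 0.5 h. For the measured compounds named here, the one measured step, a step that the two limits leave unreadable from compound 1 to compound 2, therefore has no readable size, and the limit of > 0.5 h in this assay, at which 2 of the 2 values shown sit, shows both values sitting at the same limit. Compound 3 `Cc1cc(Cl)ccc1-c1nc(NCCNc2ccc([N+](=O)[O-])c(N)n2)ncc1-c1ncc[nH]1` differs from compound 2 by 4-chloro-2-methylphenyl in place of 2-chloro-5-fluorophenyl on an aromatic carbon. With no readable step to lean on, no change beyond the scatter is expected, so the expected step is a step that the limit leaves unreadable from compound 2 to compound 3. Compound 3 is estimated at 1 h, ranging from 0.4 h to 3 h, most likely again reported only as a limit.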

Compound 3, half-life: > 0.5 h
Compound 3: only a limit was reported; the forecaster's own chance of this, stated with the estimate: 80%; the middle value lies beyond the limit too.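

In this assay, for the compounds shown here, compound 3 gives only a limit, > 0.5 h, so no step among compound 1, compound 2 and compound 3 can be read: the limit of > 0.5 h in this assay, at which 3 of the 3 values shown sit. On these data alone, the actual half-lives of all three compounds, and whether their different aromatic groups separate them at all, remain open.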